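Benzylsulfanyl for ethoxy on a purine-like core: tolerance expected

This account rests on a few compounds, and the source may have more. Where it says the series, first, only, none or still open, it means among the compounds named here.

Of the compounds shown here, three sharing one core have been tested in an ADME assay on CCRF-HSB-2 cells (Homo sapiens) for cytotoxicity, with a stated time of 7 days; a higher number here means that more compound is tolerated, a lower number that less compound is tolerated. Compound 1 `CCCCSc1nc(N)nc2c1ncn2/C=C1/CC1(CO)CO` carries a butylsulfanyl group and gives 89000 nM in this assay. Compound 2 `COCCOc1nc(N)nc2c1ncn2/C=C1/CC1(CO)CO` carries a 2-methoxyethoxy group; for compound 2 this assay reports only a limit, > 20000 nM. Compound 3 `CCOc1nc(N)nc2c1ncn2/C=C1/CC1(CO)CO` carries an ethoxy group; for compound 3 this assay likewise reports only a limit, > 20000 nM. The three single changes among them are therefore hard to weigh: a step that the limit leaves unreadable from compound 1 to compound 2 and a step that the limit leaves unreadable from compound 1 to compound 3, while a step that the two limits leave unreadable from compound 2 to compound 3. Compound 3 thus stands at the limit shared by two of the three values, as shown by the limit of > 20000 nM in this assay, at which 2 of the 3 values shown sit, and no measured step can be sized.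

Compound 4 `Nc1nc(SCc2ccccc2)c2ncn(/C=C3/CC3(CO)CO)c2n1` brings a new change, (benzylsulfanyl in place of ethoxy on an aromatic carbon). For the measured compounds named here, no measured step involves a benzylsulfanyl group, so the only guide is that compound 1, the one sulfanyl-bearing analogue, gives 89000 nM in this assay. Compound 4 is therefore expected to be tolerated at a similar high level, with an estimated step that the limit leaves unreadable from compound 3 to compound 4 in this assay. The estimate for compound 4 is 60000 nM, with a range from 15000 nM to 200000 nM.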

Compound 4, half-maximal cytotoxic concentration: > 100000 nM
Compound 4 was reported as a limit; the forecaster's own chance of this, stated with the estimate: 40%; at least 1.6-fold (0.22 log units) between middle value and limit.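

Set against compound 1 in this assay, phenyl in place of propyl on the saturated chain carbon bound to a sulfur gives an at least 1.1-fold higher number from compound 1 to compound 4 (0.05 log units; that floor lies within the scatter), so a six-membered aromatic ring can sit at the end of this sulfanyl group with no sign of lower tolerance, though no real rise can be claimed either. For compound 4, the assay reports only a limit, and it is the highest figure shown for any compound in this set: the limit of > 100000 nM in this assay, at which 1 of the 4 values shown sits. The steps linking compound 4 to compound 2 and compound 3 cannot be read, as all three values are limits.

The compounds shown therefore leave open whether a sulfur link differs from an oxygen link at this aromatic carbon, and how far compound 4 really stands from compound 1, since neither comparison has a true number on both sides. Going by these compounds, it also remains open whether tolerance would hold with an amine at the same carbon, or with a 2-phenylethylsulfanyl group, which has a longer chain between the sulfur and the phenyl ring.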